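Ethyl versus methyl carbamate across two thiazolidinedione cores

This account rests on a few compounds, and the source may have more. Where it says the series, first, only, none or still open, it means among the compounds named here.

The series pairs a carbamate-capped piperidine with a thiazolidinedione benzylidene through two different central cores. Compound 1 `COC(=O)N1CCC(Oc2ncnc(Oc3ccc(/C=C4\SC(=O)NC4=O)cc3)c2C)CC1` and compound 2 `CCOC(=O)N1CCC(Oc2ncnc(Oc3ccc(/C=C4\SC(=O)NC4=O)cc3)c2C)CC1` share one core; compound 3 `COC(=O)N1CCC(Oc2cc(Oc3cccc(/C=C4\SC(=O)NC4=O)c3)ncn2)CC1` and the unmeasured compound 4 `CCOC(=O)N1CCC(Oc2cc(Oc3cccc(/C=C4\SC(=O)NC4=O)c3)ncn2)CC1` share another. The difference between the two cores is not broken down here.

In a functional assay on CHO-K1 cells for agonist activity at Glucose-dependent insulinotropic receptor (Homo sapiens), read by cAMP accumulation and immunoassay, with a stated time of 1 h (a higher number here means that more compound is needed for the effect, a lower number that less compound is needed), compound 1 gives 1410 nM, compound 2 gives 157 nM, and compound 3 gives 1870 nM. For the measured compounds named here, the only counted change on the first core is methyl in place of hydrogen on a saturated chain carbon bound to an oxygen next to a carbonyl group, and it produced a 9.0-fold lower number from compound 1 to compound 2 (0.95 log units; beyond the scatter).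

Compound 4 carries the same change on the second core, methyl in place of hydrogen on a saturated chain carbon bound to an oxygen next to a carbonyl group: the "place" of the change reads identically for both pairs, so it is taken as the same change, not merely the same kind. Given that compound 1 and compound 3 sit within the scatter of each other, the step is expected to transfer largely intact, estimated as a 7.5-fold lower number from compound 3 to compound 4 (0.87 log units; beyond the scatter), resting on the single earlier step of a 9.0-fold lower number from compound 1 to compound 2 (0.95 log units; beyond the scatter) and therefore held loosely. Compound 4 is accordingly expected to give about 250 nM, between 80 nM and 800 nM.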

Compound 4, half-maximal effective concentration: 819 nM
Compound 4: the middle estimate sits 3.3-fold (0.52 log units) below what was measured, outside the stated range (above it).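

Moving from methoxycarbonyl to ethoxycarbonyl lowers the number on the second core as well as the first in this assay (a 2.3-fold lower number from compound 3 to compound 4 (0.36 log units; beyond the scatter)), so the direction of the change carries over in both pairs shown. Its size does not carry over, and the two steps have to be read as different: the same change on two cores in this assay, a 9.0-fold lower number (0.95 log units; beyond the scatter) from compound 1 to compound 2 and a 2.3-fold lower number (0.36 log units; beyond the scatter) from compound 3 to compound 4, 3.9-fold (0.59 log units) apart, beyond the scatter of two such steps. For the compounds shown here, with only two pairs, this shows that the step on one core is a poor guide to its size on the other, but it does not show which feature of the cores sets the size, nor how the step would behave on a third core.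

The compounds shown leave open whether a longer chain such as propyl, or a branched one such as isopropyl, in place of ethyl lowers the number further on either core. They also leave open whether the gap between the two cores persists when the carbamate gives way to an amide.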